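The compounds below may be only part of what the source reports. "The series", "measured", "known", "first", "only" and "open" are said of these compounds alone.

Compound 1, `O=S(=O)(NCCCNc1nccc(-c2c(-c3cccc(F)c3)nc3sccn23)n1)c1cccc(F)c1`, carries a sulfonamide whose sulfur bears a 3-fluorophenyl group. In a functional assay on SK-MEL-28 cells (Homo sapiens) for cytotoxicity, read by MTT assay (a higher number here means a weaker inhibitor, a lower number a stronger inhibitor), compound 1 gives 8550 nM. Compound 2, `Cc1ccc(S(=O)(=O)NCCCNc2nccc(-c3c(-c4cccc(F)c4)nc4sccn34)n2)cc1`, differs only in having a 4-methylphenyl on that sulfonyl sulfur, and in this assay compound 2 gives 9500 nM. The step of a 1.1-fold higher number from compound 1 to compound 2 (0.05 log units; within the scatter) lies within the scatter, so on the two numbers shown compound 2 and compound 1 sit together, with compound 1 as its only neighbour. Compound 3, `O=S(=O)(NCCCNc1nccc(-c2c(-c3cccc(F)c3)nc3sccn23)n1)c1ccccc1`, is the next change at the same ring: hydrogen in place of methyl on an aromatic carbon. Among the measured compounds shown here, the one step that bears on this, swapping one group for another on the sulfonyl aryl ring, was a 1.1-fold higher number from compound 1 to compound 2 (0.05 log units; within the scatter), which moved nothing beyond the scatter. Removing the methyl is expected to behave alike, so the step of a 1.1-fold lower number from compound 2 to compound 3 (0.02 log units; within the scatter) is expected to stay within the scatter. Compound 3 is therefore estimated at 9000 nM in this assay, between 4500 nM and 18000 nM.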

Compound 3, half-maximal inhibitory concentration: 6850 nM
Compound 3: middle estimate off by 1.3-fold (0.12 log units), on the high side; low and high end bracket the measured number.
By their numbers in this assay, from the lowest: compounds 3, 1 and 2 (each within the scatter of the next).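

In this assay, taking the methyl off the ring gives a small step (a 1.4-fold lower number from compound 2 to compound 3 (0.14 log units; within the scatter)), and going from the 3-fluorophenyl group to plain phenyl gives another (a 1.2-fold lower number from compound 1 to compound 3 (0.10 log units; within the scatter)). With compound 3 in hand, the ring has now been seen bare as well as carrying a methyl or a fluoro group, and no step among these three compounds leaves the scatter. So in this assay, compounds 1, 2 and 3 cannot be told apart, and the bare ring shows that neither the methyl nor the fluoro group is needed for the activity seen here; no evidence is available to explain these numbers.

Methyl and fluoro are both small groups, so these compounds leave open whether this position would respond to something larger or charged, such as an amine or a carboxylic acid. They also leave open what would happen if a longer chain replaced the ring.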